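The source may hold more compounds than are shown below. What is called first, only, known or untested is meant among the compounds shown, and "the series" means these compounds.

In an ADME assay on Huh-7 cells (Homo sapiens) for cytotoxicity (on this read-out higher numbers stand for lower toxicity in this test and lower numbers for higher toxicity in this test), three compounds built on one shared core have been measured. Compound 1, `CN1CCN(CCCNCc2cn(-c3ccc(C(F)(F)F)cc3)nc2-c2ccc(OC(F)(F)F)cc2)CC1`, gives 2300 nM. Compound 3, `CCCN1CCC(CNCc2cn(-c3ccc(C(F)(F)F)cc3)nc2-c2ccc(C(F)(F)F)cc2)CC1`, gives 1200 nM. Compound 2, `CN1CCN(CCNCc2cn(-c3ccc(F)cc3F)nc2C2CCCCC2)CC1`, gives a reading of > 20000 nM, which is a limit of the test rather than a number. Compound 2 thus sits at the edge of what the test reports, as seen in the limit of > 20000 nM in this assay, at which 1 of the 3 values shown sits.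

The next compound, compound 4, `CN1CCN(CCNCc2cn(-c3ccc(F)cc3F)nc2-c2ccc(N(C)C)cc2)CC1`, has not yet been measured. It differs from compound 2 in one place: 4-(dimethylamino)phenyl in place of cyclohexyl on an aromatic carbon. Among the compounds with values here, no two measured compounds differ in just one place, so no measured step guides this change. Compounds 1 and 3 also carry an aromatic ring on that aromatic carbon rather than cyclohexyl. Compound 1 sits at 2300 nM and compound 3 sits at 1200 nM. On that basis a move toward those values is expected. The step from compound 2 to compound 4 is estimated as an at least 2.5-fold lower number from compound 2 to compound 4 (0.39 log units; beyond the scatter), toward higher toxicity. Compound 4 is estimated at 8000 nM, within a range from 2500 nM to 20000 nM.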

Compound 4, half-maximal cytotoxic concentration: > 20000 nM
Compound 4 was reported as a limit (the forecaster's own chance of this, stated with the estimate: 30%); at least 2.5-fold (0.39 log units) between middle value and limit.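

In this assay, compound 2 and compound 4 both give a limit of the test rather than a number, so no step can be read between them: the limit of > 20000 nM in this assay, at which 2 of the 4 values shown sit. The compounds shown leave open whether 4-(dimethylamino)phenyl in place of cyclohexyl changes this reading at all, and in which direction.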